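The compounds below may be only part of what the source reports. "The series", "measured", "known", "first", "only" and "open" are said of these compounds alone.

Measured in a functional assay on MCF7 cells (Homo sapiens) for cytotoxicity, read by MTT assay, with a stated time of 72 h; a lower number here means a stronger inhibitor, a higher number a weaker inhibitor:
- compound 1 `CNC(=O)c1cc(Oc2ccc(NC(=O)c3cc(-c4ccc(Br)cc4)ncn3)cc2)ccn1`: > 100000 nM, a limit
- compound 2 `CNC(=O)c1cc(Oc2ccc(NC(=O)c3cc(-c4ccc(F)cc4)ncn3)cc2)ccn1`: > 100000 nM, a limit
- compound 3 `CNC(=O)c1cc(Oc2ccc(NC(=O)c3cc(-c4ccc(OC)cc4)ncn3)cc2F)ccn1`: 46200 nM

Among these, only compound 3 gives an actual number. Compound 1 and compound 2 both stand at the limit of > 100000 nM in this assay, at which 2 of the 3 values shown sit, and both have hydrogen at the place in question.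

Compound 4 `CNC(=O)c1cc(Oc2ccc(NC(=O)c3cc(-c4ccc(OC)cc4)ncn3)cc2)ccn1` has hydrogen in place of fluoro on an aromatic carbon. Among the compounds with values here, the only measured step, a step that the two limits leave unreadable from compound 1 to compound 2, lies elsewhere and offers no size to carry over.

Little change is therefore expected, with a slight lean towards weaker inhibition, and the estimated step is a 1.5-fold higher number from compound 3 to compound 4 (0.18 log units; within the scatter). For compound 4 the expected value is 70000 nM, within an estimated range from 25000 nM to 150000 nM.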

Compound 4, half-maximal inhibitory concentration: 29200 nM
Estimate against measurement, compound 4: 2.4-fold (0.38 log units) above; the measured number falls inside the stated range.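

In this assay, replacing the fluoro with hydrogen, on an aromatic carbon ortho to a (2-(methylcarbamoyl)pyridin-4-yl)oxy group, stays within the scatter: a 1.6-fold lower number from compound 3 to compound 4 (0.20 log units; within the scatter). With hydrogen at this place, methoxy in place of fluoro and methoxy in place of bromo give readable steps beyond the scatter, an at least 3.4-fold lower number from compound 2 to compound 4 (0.53 log units; beyond the scatter) and an at least 3.4-fold lower number from compound 1 to compound 4 (0.53 log units; beyond the scatter). Both sizes are only bounds, since compound 1 and compound 2 each stand at a limit: the limit of > 100000 nM in this assay, at which 2 of the 4 values shown sit.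

The compounds shown leave open how chlorine or an amine would read at this place. They also leave open how an ethoxy group would compare with methoxy.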